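Switching the amide substituent back to hydroxy

A few compounds are considered here, and "the series" means these few. Any claim that something is new, unique, unknown or untested is made for them only; others in the source may bear on it.

Measured so far:
Compound 1 `CC(C)=CCCC1=CC[C@H](C(=O)NO)[C@@H](c2ccccc2)C1`, 600 nM
Compound 2 `CONC(=O)[C@@H]1CC=C(CCC=C(C)C)C[C@H]1c1ccccc1`, 2700 nM
Compound 3 `COC(=O)c1ccc(NC(=O)[C@@H]2CC=C(CCC=C(C)C)C[C@H]2c2ccccc2)cc1`, > 23000 nM

In an assay on isolated protein for inhibition of Apoptosis regulator Bcl-2 (Homo sapiens), read by fluorescence polarization, with stated times of 5 min and 10 min (a lower number here means a stronger inhibitor, a higher number a weaker inhibitor), compound 3 reaches only a limit, > 23000 nM, so no number is known for it. The next compound, compound 4 `CC(C)=CCCC1=CC[C@@H](C(=O)NO)[C@H](c2ccccc2)C1`, differs from it in one place: hydroxy in place of 4-(methoxycarbonyl)phenyl on an amide-type nitrogen. Going by the values given here, one measured step bears on this change: an at least 8.5-fold higher number from compound 2 to compound 3 (0.93 log units; beyond the scatter), where the same aryl group entered in place of methoxy and weakened binding. Removing it again should therefore strengthen binding, and compound 1, which also carries hydroxy on the amide nitrogen, gives 600 nM, though compound 4 differs from it in stereochemistry. The step of an at least 7.6-fold lower number from compound 3 to compound 4 (0.88 log units; beyond the scatter) is expected to be a clear gain. Compound 4 is expected to give about 3000 nM, within 500 nM to 20000 nM.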

Compound 4, inhibition constant: 700 nM
Compound 4: the middle estimate sits 4.3-fold (0.63 log units) above what was measured; the measured number falls inside the stated range.
By their numbers in this assay, from the lowest: compounds 1 and 4 (each within the scatter of the next); then compound 2. At a limit, above all of these: compound 3.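

In this assay, hydroxy on the amide-type nitrogen binds better than methoxy, with a 3.9-fold lower number from compound 2 to compound 4 (0.59 log units; beyond the scatter), and far better than the aryl group, with an at least 32-fold lower number from compound 3 to compound 4 (1.51 log units; beyond the scatter). Compound 3 gives only a limit, > 23000 nM. The mirror-image pair shows a 1.2-fold higher number from compound 1 to compound 4 (0.07 log units; within the scatter), so inverting both stereocentres makes no difference beyond the scatter: the fact that compounds 1 and 4 differ only in the configuration as drawn

Still open, on these data alone, is how an amide hydrogen, an ethoxy group or a small amine on this nitrogen would compare with hydroxy. Equally open, as far as these compounds go, is whether any aryl group there would bind as poorly as 4-(methoxycarbonyl)phenyl.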